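The source may report more compounds than this note shows. Statements on the series, on what has been measured and on what is new or still open speak of the compounds shown alone.

For the measured compounds named here, the three compounds measured so far all come out in the same narrow band in a functional assay on RAW264.7 cells (Mus musculus) for inhibition; a higher number here means a weaker inhibitor, a lower number a stronger inhibitor. Compound 1 `O=C(c1ccc(CN2Cc3ccccc3S2(=O)=O)cc1)N1CCCCC1` gives 44300 nM in this assay, compound 3 `O=C(NCc1ccco1)c1ccc(CN2Cc3ccccc3C2=O)cc1` gives 49700 nM, and compound 2 `CC(C)(C)OC(=O)N(Cc1ccco1)C(=O)c1ccc(CN2Cc3ccccc3C2=O)cc1` gives 51800 nM, the highest of the three numbers, though its gaps to compound 3 and to compound 1 both sit within the scatter, so no ordering among them can be claimed.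

Going by the values given here, the only step that can be read within one change is the one from compound 2 to compound 3, hydrogen in place of tert-butoxycarbonyl on an amide-type nitrogen, which gave a 1.0-fold lower number from compound 2 to compound 3 (0.02 log units; within the scatter). Compound 1 differs from compound 2 in more than one place, so its value stands only as a further point in the same band.

Compound 4 `CC(C)(C)OC(=O)N(Cc1ccco1)C(=O)c1ccc(Cn2sc3ccccc3c2=O)cc1` is the unmeasured analogue. Relative to compound 2 the change is a group of 10 heavy atoms (7 carbon, 1 nitrogen, 1 oxygen, 1 sulfur; one five-membered aromatic ring with 2 hetero atoms, one six-membered aromatic ring of carbon only) in place of a group of 10 heavy atoms (8 carbon, 1 nitrogen, 1 oxygen; one five-membered non-aromatic ring with 1 hetero atom, one six-membered aromatic ring of carbon only), on a saturated chain carbon bound to an aromatic carbon. Among the compounds with values here, none of the measured steps touches this part of the molecule, so there is nothing here to predict a direction from. The expectation is therefore that the step from compound 2 to compound 4 in this assay will be a 1.0-fold lower number from compound 2 to compound 4 (0.02 log units; within the scatter), that is, nothing beyond the scatter. On that basis compound 4 is estimated at 50000 nM in this assay, with a range from 20000 nM to 150000 nM.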

Compound 4, half-maximal inhibitory concentration: 68000 nM
For compound 4 the middle estimate is 1.4-fold (0.13 log units) below the measured one; measured number inside the range.
By their numbers in this assay, from the lowest: compounds 1, 3, 2 and 4 (each within the scatter of the next).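

In this assay, the change on the saturated chain carbon bound to an aromatic carbon, with the group holding a five-membered aromatic ring with 2 hetero atoms entering in place of the group holding a five-membered non-aromatic ring with 1 hetero atom, gave a 1.3-fold higher number from compound 2 to compound 4 (0.12 log units; within the scatter). For the compounds shown here, this is the first readable step at this position, as the earlier step concerned only the tert-butoxycarbonyl on the amide-type nitrogen, and it shows that this exchange, which brings in sulfur and raises the count of hydrogen-bond acceptors, does not move the number beyond the scatter. No measurement is available that could account for this outcome.

With every compound still in one narrow band, the shown compounds do not reveal whether any group at this position can shift the number beyond the scatter, for example an amine or a carboxylic acid carried on the entering group. As far as these compounds go, it also remains open whether the same exchange would give a similar step with hydrogen in place of tert-butoxycarbonyl on the amide-type nitrogen.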